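Fluoro in Place of Hydrogen on an Aromatic Ring

The compounds below may be only part of what the source reports. "The series", "measured", "known", "first", "only" and "open" are said of these compounds alone.

Of the compounds shown here, two sharing one core have so far been tested in a functional assay on the whole organism (strain Kunming) with Mus musculus as the target; on this read-out lower numbers stand for an effect already at smaller amounts and higher numbers for an effect only at larger amounts of compound. Compound 1 `O=C1CC(c2cccc(C(F)(F)F)c2)n2ncnc2N1` gives 54.8 mg/kg in this assay. Compound 2 `O=C1CC(c2ccccc2)n2ccnc2N1` gives 68.2 mg/kg in this assay; this is the highest of the two numbers, but the gap to compound 1 lies within the scatter of repeated measurements, so no order between the two can be read from it. Compound 3 `O=C1CC(c2ccccc2F)n2ccnc2N1` has not been measured. It differs from compound 2 in one place: fluoro in place of hydrogen on an aromatic carbon. Among the compounds with values here, no pair of measured compounds shows what such a change does here, so the direction of the step is open. Within the data shown here, with only two close numbers to rest on, the expected step from compound 2 to compound 3 in this assay is a 1.0-fold lower number from compound 2 to compound 3 (0.02 log units; within the scatter), not beyond the scatter. The value of compound 3 in this assay is estimated at 65 mg/kg, within 38 mg/kg to 110 mg/kg.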

Compound 3, dose for half-maximal effect: 88 mg/kg
The estimate for compound 3 lay 1.4-fold (0.13 log units) below the measured number, and the stated range covers the measured number.
By their numbers in this assay, from the lowest: compounds 1, 2 and 3 (each within the scatter of the next).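

Fluoro in place of hydrogen on an aromatic carbon, ortho to a large group, is the one step between compounds differing in one place shown in this assay (a 1.3-fold higher number from compound 2 to compound 3 (0.11 log units; within the scatter)), and it stays inside the usual spread of repeated measurements. So at this place on the six-membered aromatic ring of carbon only, swapping a hydrogen atom for one fluorine atom gives no effect that this read-out can tell apart from scatter. No measurement at hand bears on why this is so.

From the compounds shown here alone, whether fluoro acts the same way at other places on this ring remains open. So does whether a different group at this same place, such as an amine, a carboxylic acid or a longer chain, would give a step beyond the scatter.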